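The compounds below may be only part of what the source reports. "The series", "measured", "known", "first", "only" and "open" are said of these compounds alone.

Working notes on the series. In an assay on lysate for inhibition of phosphatidylcholine:ceramide cholinephosphotransferase 2 (Homo sapiens), read by HPLC, with stated times of 30 min and 2 h (a lower number here means a stronger inhibitor, a higher number a weaker inhibitor), compound 1 `O=C(NCc1ccccc1)c1ccccc1OCc1ccccc1` gives 34200 nM, and compound 2 `O=C(Nc1ccccn1)c1ccccc1OCc1ccccc1` gives 11700 nM in this assay. Going by the values given here, the one single-point step among the measured compounds is a 2.9-fold lower number from compound 1 to compound 2 (0.47 log units; beyond the scatter), a change on the amide-type nitrogen. Compound 3 `N#Cc1cccc(COc2ccccc2C(=O)Nc2cccnc2)c1` gives 60700 nM in this assay. Compound 3 stands at the upper end of the three numbers: its value and that of compound 1 fall within the usual scatter of each other, so no order between them can be read, while compound 2 lies lower by more than the scatter.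

Compound 4 `Cc1ccc(F)cc1COc1ccccc1C(=O)Nc1cccnc1` follows from compound 3 by 5-fluoro-2-methylphenyl in place of 3-cyanophenyl on a saturated chain carbon bound to an oxygen on an aromatic ring. Among the compounds with values here, no measured step touches this ring: the step from compound 1 to compound 2 concerns the amide-type nitrogen only and does not bear on the change. Within the data shown here, compounds 1 and 3 differ in two places at once, and their two values sit within the scatter of each other, which is the only information on the ether aryl ring. On that basis the change from compound 3 to compound 4 is expected to give no step beyond the scatter in this assay, namely a 1.3-fold lower number from compound 3 to compound 4 (0.13 log units; within the scatter). The estimate for compound 4 in this assay is 45000 nM, with a range from 12000 nM to 150000 nM.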

Compound 4, half-maximal inhibitory concentration: 740 nM
The estimate for compound 4 lay 61-fold (1.78 log units) above the measured number, and the stated range ends above it.
By their numbers in this assay, from the lowest: compound 4; then compound 2; then compounds 1 and 3 (each within the scatter of the next).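

The aryl group on a saturated chain carbon bound to an oxygen on an aromatic ring turns out to be a strong determinant of the number in this assay, with an 82-fold lower number from compound 3 to compound 4 (1.91 log units; beyond the scatter) on exchanging 3-cyanophenyl for 5-fluoro-2-methylphenyl; compounds 1 and 3 differ in two places at once and could not show this. The two groups have the same count of heavy atoms and the same six-membered aromatic ring of carbon only, so the large step comes with a change in what the ring carries, not in the ring itself or in the heavy-atom count of the group. No measurement bears on the cause of this step.

The single exchange removes the nitrile and introduces both the methyl and the fluorine, so the compounds shown do not tell whether the step follows the loss of the nitrile, the methyl, the fluorine or their combination. They also leave open how this position responds to other groups on the ring, such as a chlorine, a methoxy group, an amine or a carboxylic acid, and whether the step on the amide-type nitrogen, a 2.9-fold lower number from compound 1 to compound 2 (0.47 log units; beyond the scatter), carries over to compound 4.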